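The compounds below may be only part of what the source reports. "The series", "measured", "known", "first", "only" and "open" are said of these compounds alone.

Measured compounds in an ADME assay on Vero cells (Chlorocebus sabaeus) for cytotoxicity, read by MTT assay; a higher number here means a weaker inhibitor, a lower number a stronger inhibitor
Compound 1 `C=CCOc1cc(OC)c(C(=O)/C=C/C=C/c2ccccc2)c(OCC=C)c1` — "not determined" (no result reported)
Compound 2 `C=CCOc1cc(OC)c(C(=O)/C=C/c2ccc(C(F)(F)F)cc2)c(OCC=C)c1` — 7200 nM

For the measured compounds named here, compound 2 holds the only number in this assay, since compound 1 has no result, so it cannot yet be ranked against anything. Compound 3 `C=CCOc1cc(OC)c(C(=O)/C=C/c2ccccc2Br)c(OCC=C)c1` carries 2-bromophenyl in place of 4-(trifluoromethyl)phenyl, and the change is 2-bromophenyl in place of 4-(trifluoromethyl)phenyl on a double-bonded chain carbon bound to a double-bonded chain carbon (on a double-bonded chain carbon bound to a double-bonded chain carbon). Going by the values given here, no measured step shows what such a swap does, so the expected step of a 1.0-fold lower number from compound 2 to compound 3 (0.01 log units; within the scatter) is estimated to stay within the usual scatter, with either direction open. For compound 3 the expected value is 7000 nM (2800 nM to 18000 nM).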

Compound 3, half-maximal inhibitory concentration: 13900 nM
For compound 3 the middle estimate is 2.0-fold (0.30 log units) below the measured one; measured number inside the range.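

For the compounds shown here, this is the first measured step at this position: in this assay, 2-bromophenyl in place of 4-(trifluoromethyl)phenyl on a double-bonded chain carbon bound to a double-bonded chain carbon gives a 1.9-fold higher number from compound 2 to compound 3 (0.29 log units; within the scatter). The two aryl groups therefore cannot be told apart here, even though they differ in heavy atoms and in halogen. Nothing available bears on why this is so. The compounds shown leave open whether a phenyl ring carrying an amine or a carboxylic acid at this place would give a step beyond the scatter.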